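A few compounds are considered here, and "the series" means these few. Any claim that something is new, unique, unknown or untested is made for them only; others in the source may bear on it.

Three compounds have numbers in an assay on cell membranes for displacement of a labelled ligand from Sigma non-opioid intracellular receptor 1 (Cavia porcellus), read by scintillation counting, with a stated time of 120 min; on this read-out higher numbers stand for weaker inhibition and lower numbers for stronger inhibition. Compound 1 `COc1cc2c(cc1OC)CN(CCCCn1nc(-c3ccccc3)oc1=O)CC2` gives 1600 nM and compound 2 `O=c1oc(-c2ccccc2)nn1CCCCN1CCc2ccc([N+](=O)[O-])cc2C1` gives 829 nM; compound 3 `O=C1CCc2ccccc2N1CCCCN1CCN(C2CCCCC2)CC1` gives 21 nM, the lowest of the three, with the gap to compound 2 and the wider gap to compound 1 both beyond the scatter. Compound 4 `O=C1CCc2ccccc2N1CCCCN1CCN(c2ccccn2)CC1` has not been measured. It departs from compound 3 in one place: pyridin-2-yl in place of cyclohexyl on an amine nitrogen in a ring. For the measured compounds named here, no measured pair shows this change, so the expected size of the step rests on compound 3 alone, which gives 21 nM, and on the change itself. The expectation is a move toward weaker inhibition that goes beyond the scatter, estimated as a 7.1-fold higher number from compound 3 to compound 4 (0.85 log units; beyond the scatter). Compound 4 is expected at 150 nM, with a range from 30 nM to 800 nM.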

Compound 4, inhibition constant: 120 nM
Beside the measured number, compound 4's estimate is 1.3-fold (0.10 log units) above it; the range from low to high includes it.
By their numbers in this assay, from the lowest: compound 3; then compound 4; then compounds 2 and 1 (each within the scatter of the next).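

In this assay, for the compounds shown here, the swap of cyclohexyl for pyridin-2-yl on an amine nitrogen in a ring gives a 5.7-fold higher number from compound 3 to compound 4 (0.76 log units; beyond the scatter) and is the first single-place step. The heavy-atom count stays the same across this change while an aromatic ring and a hydrogen-bond acceptor enter, so this position responds to more than the count of atoms. Nothing at hand accounts for the step. Open, as far as these compounds go, is where phenyl would fall, which would separate the aromatic ring from the ring nitrogen of pyridin-2-yl. Also open, from the compounds shown here alone, is whether the step holds with a longer chain to the shared core.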